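Selenium replaced by methylsulfanyl on the shared core

The source may report more compounds than this note shows. Statements on the series, on what has been measured and on what is new or still open speak of the compounds shown alone.

For the measured compounds named here, compound 2 `[SeH]c1nc(NCc2ccccc2)c2cccnc2n1` gives 8400 nM in an ADME assay on BEAS-2B cells (Homo sapiens) for cytotoxicity, read by MTT assay, with a stated time of 72 h (a higher number here means a weaker inhibitor of growth, a lower number a stronger inhibitor of growth), the only number so far. Compound 1 `CCCCC[Se]c1nc([Se]CCCCC)c2cccnc2n1` returns only a limit, > 100000 nM, which the limit of > 100000 nM in this assay, at which 1 of the 2 values shown sits, records as a limit and not a number. Compound 3 `CSc1nc(NCc2ccccc2)c2cccnc2n1` differs from compound 2 by a group of 2 heavy atoms (1 carbon, 1 sulfur; no ring) in place of one selenium atom, on an aromatic carbon. Going by the values given here, no measured pair isolates this change, so the size of a 2.4-fold higher number from compound 2 to compound 3 (0.38 log units; beyond the scatter) is an expectation rather than a reading; a shift toward weaker growth inhibition, beyond the scatter, is expected. Compound 3 is thus estimated at 20000 nM, within 5000 nM to 80000 nM in this assay.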

Compound 3, concentration for 50% growth inhibition: 25900 nM
Compound 3: middle estimate off by 1.3-fold (0.11 log units), on the low side, and the stated range covers the measured number.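

In this assay the position between two ring nitrogen atoms now has its first measured step: methylsulfanyl in place of selenium gives a 3.1-fold higher number from compound 2 to compound 3 (0.49 log units; beyond the scatter) as a modest shift toward weaker growth inhibition. The change still leaves a measurable number on the shared core. Nothing measured here bears on the reason for this step.

For the compounds shown here, compound 1, at > 100000 nM, is a limit and differs in more than one place, so no step to it can be read. Open, on these data alone, is how an amine or a longer chain on sulfur would read at this position, and whether the sulfur or the added carbon carries the step.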